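The source may report more compounds than this note shows. Statements on the series, on what has been measured and on what is new or still open speak of the compounds shown alone.

Measured compounds in a functional assay on PC-12 cells (Rattus norvegicus) for cytotoxicity, read by MTT assay, with stated times of 3 h and 2 h, tested at 1 uM; on this read-out lower numbers stand for a weaker effect and higher numbers for a stronger effect at the one concentration tested:

compound 1 `CC(=O)c1cc2ccc(OCCCCCn3cc(CNC(=O)CCCCC4CCSS4)nn3)cc2oc1=O`: 27.4%
compound 2 `CCOC(=O)c1cc2ccc(OCCCCCn3cc(CNC(=O)CCCCC4CCSS4)nn3)cc2oc1=O`: 35.1%
compound 3 `O=C(CCCCC1CCSS1)NCc1cn(CCCCCOc2ccc3cc(-c4ccccc4)c(=O)oc3c2)nn1`: 30.7%

Compound 3 stands second highest of the three numbers, set apart from the others by a number 3.3 percentage points higher from compound 1 to compound 3 (within the scatter) and by a number 4.4 percentage points lower from compound 2 to compound 3 (within the scatter), so all three measured compounds lie within the scatter of one another on this read-out.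

Compound 4 `COc1ccc(-c2cc3ccc(OCCCCCn4cc(CNC(=O)CCCCC5CCSS5)nn4)cc3oc2=O)cc1` differs from compound 3 by methoxy in place of hydrogen on an aromatic carbon. Within the data shown here, no measured step exchanges methoxy for hydrogen. Among the measured compounds shown here, the steps that bear on this position are the exchanges at the same aromatic carbon of the shared core, a number 3.3 percentage points higher from compound 1 to compound 3 (within the scatter) and a number 4.4 percentage points lower from compound 2 to compound 3 (within the scatter), together with a number 7.7 percentage points higher from compound 1 to compound 2 (within the scatter) on the carbonyl carbon; every one of them is within the scatter. Three quite different groups at that carbon give numbers that cannot be told apart, so a further addition of methoxy one bond further out is not expected to move this assay beyond the scatter in either direction.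

Compound 4 is estimated at 31%, with a range of 20% to 42%. The expected step is a number 0.3 percentage points higher from compound 3 to compound 4 (within the scatter), within the scatter.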

Compound 4, a percentage reported as activity, at one concentration (the size of the read-out at that concentration, not a potency): 37.1%
Beside the measured number, compound 4's estimate is 6.1 percentage points below it, within the range that was stated.
By their numbers in this assay, from the lowest: compounds 1, 3, 2 and 4 (each within the scatter of the next).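

In this assay, the change from phenyl to 4-methoxyphenyl gives a number 6.4 percentage points higher from compound 3 to compound 4 (within the scatter), so adding methoxy on this aromatic carbon, para to a large group, does not separate the two compounds. Measured against the other groups at the shared core carbon, 4-methoxyphenyl in place of ethoxycarbonyl gives a number 2 percentage points higher from compound 2 to compound 4 (within the scatter) and 4-methoxyphenyl in place of acetyl gives a number 9.7 percentage points higher from compound 1 to compound 4 (within the scatter), so all four groups at that carbon now give numbers that cannot be told apart on this read-out. Nothing available accounts for these numbers.

On these data alone, whether an amine, a carboxylic acid or a longer chain in place of methoxy on the phenyl would give a step beyond the scatter remains open. With one concentration only, the numbers also leave open whether any of the compounds would show a stronger or weaker effect than the others at a different concentration.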